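A few compounds are considered here, and "the series" means these few. Any claim that something is new, unique, unknown or untested is made for them only; others in the source may bear on it.

Working notes on the cyclic sulfonate series built on the shared core of compound 1 `Cc1cn([C@@H]2O[C@H](CO[Si](C)(C)C(C)(C)C)[C@@]3(OS(=O)(=O)C=C3NCC(=O)O)[C@H]2O[Si](C)(C)C(C)(C)C)c(=O)n(C)c1=O`, in which a functional assay on HEL cells (Homo sapiens) for cytotoxicity, read by microscopy (on this read-out lower numbers stand for higher toxicity in this test and higher numbers for lower toxicity in this test), is the only read-out in hand. Compound 1 gives 300000 nM. Compound 2 `CC(=O)NC1=CS(=O)(=O)O[C@@]12[C@@H](CO[Si](C)(C)C(C)(C)C)O[C@@H](n1cc(C)c(=O)n(C)c1=O)[C@@H]2O[Si](C)(C)C(C)(C)C` gives >= 80000 nM, a limit of the assay rather than a number, as recorded in the limit of >= 80000 nM in this assay, at which 1 of the 3 values shown sits. Compound 3 `Cc1cn([C@@H]2O[C@H](CO[Si](C)(C)C(C)(C)C)[C@@]3(OS(=O)(=O)C=C3NC(N)=O)[C@H]2O[Si](C)(C)C(C)(C)C)c(=O)n(C)c1=O` gives 16000 nM and so stands at the lowest of the two numbers shown; its nearest neighbour is compound 1, reached by a 19-fold lower number from compound 1 to compound 3 (1.27 log units; beyond the scatter). The step that the limit leaves unreadable from compound 1 to compound 2 cannot be sized because of the limit, while an at least 5.0-fold lower number from compound 2 to compound 3 (0.69 log units; beyond the scatter) reaches beyond the scatter.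

Compound 4 `Cc1cn([C@@H]2O[C@H](CO[Si](C)(C)C(C)(C)C)[C@@]3(OS(=O)(=O)C=C3NC(=O)c3ccccc3)[C@H]2O[Si](C)(C)C(C)(C)C)c(=O)n(C)c1=O` is the next member awaiting this assay. It differs from compound 3 by phenyl in place of amino on a carbonyl carbon. Within the data shown here, the only measured step at the same carbonyl carbon is an at least 5.0-fold lower number from compound 2 to compound 3 (0.69 log units; beyond the scatter), where the arrival of the amino group lowered the number; its departure here, with phenyl entering, is therefore expected to move the number upward by a modest step, a 3.8-fold higher number from compound 3 to compound 4 (0.57 log units; beyond the scatter). For compound 4 the estimate is 60000 nM, within 15000 nM to 300000 nM.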

Compound 4, minimum cytotoxic concentration: >= 3200 nM
Compound 4 was reported as a limit (the forecaster's own chance of this, stated with the estimate: 30%); the middle value does not contradict the limit.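

In this assay compound 4 gives >= 3200 nM, which is a limit and not a number, so its steps from compound 1, compound 2 and compound 3 cannot be read. The compounds shown leave open whether phenyl in place of amino on a carbonyl carbon raises or lowers the number.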